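Replacing tert-butyl with cyclopropyl on a nitrone

The compounds below may be only part of what the source reports. "The series", "measured", "known", "first", "only" and "open" are said of these compounds alone.

Measured in a functional assay for inhibition, with Rattus norvegicus as the target; a lower number here means a stronger inhibitor, a higher number a weaker inhibitor:
compound 1 `Cc1c(C)c2c(c(C)c1O)CCC(C)(/C=[N+](\[O-])C(C)(C)C)O2`: 3200000 nM
compound 2 `COc1c(C)c(C)c2c(c1C)CCC(C)(/C=[N+](\[O-])C(C)(C)C)O2`: 3700000 nM

Going by the values given here, compound 1 and compound 2 lie within the scatter of each other, so compound 1 does not stand apart from the only other compound measured. The next compound, compound 3 `Cc1c(C)c2c(c(C)c1O)CCC(C)(/C=[N+](\[O-])C1CC1)O2`, keeps the core of compound 1 and changes one group: cyclopropyl in place of tert-butyl on a double-bonded nitrogen. That is, cyclopropyl replaces tert-butyl on a double-bonded nitrogen. Among the compounds with values here, only one measured step is available, a 1.2-fold higher number from compound 1 to compound 2 (0.06 log units; within the scatter), and it is methyl in place of hydrogen on an oxygen on an aromatic ring. This step leaves the tert-butyl untouched, so no measurement speaks directly to the new change. Within the data shown here, with only this small step as a guide, no shift beyond the scatter in this assay is expected, and no direction is favoured. The expected step is a 1.1-fold lower number from compound 1 to compound 3 (0.03 log units; within the scatter). For compound 3 the estimated value is 3000000 nM, with an expected range from 1200000 nM to 7500000 nM.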

Compound 3, half-maximal inhibitory concentration: 1100000 nM
For compound 3 the middle estimate is 2.7-fold (0.44 log units) above the measured one; measured number outside the range, below it.
By their numbers in this assay, from the lowest: compound 3; then compounds 1 and 2 (each within the scatter of the next).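

In this assay, cyclopropyl in place of tert-butyl on a double-bonded nitrogen gives a 2.9-fold lower number from compound 1 to compound 3 (0.46 log units; beyond the scatter). Going by these compounds alone, this is the first change to move the number beyond the scatter, unlike the change on the oxygen on an aromatic ring, which gave a 1.2-fold higher number from compound 1 to compound 2 (0.06 log units; within the scatter). The group on this nitrogen therefore affects inhibition in this assay, with compound 3 the stronger inhibitor of the pair, but nothing available explains the step.

Only one replacement for tert-butyl is shown here, so it remains open whether the step depends on the three-membered ring itself; isopropyl or cyclobutyl on this nitrogen would test that. Going by these compounds, it is also open whether cyclopropyl gives a similar step when methyl sits on the oxygen, as in compound 2.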